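Swapping a Ring Sulfur for Oxygen in Thiosemicarbazide Amidrazones

This account rests on a few compounds, and the source may have more. Where it says the series, first, only, none or still open, it means among the compounds named here.

Measured compounds:
Compound 1, `Cc1cccc(/C(N)=N/NC(=S)N2CCSCC2)n1`, gives 42.8% in a functional assay on A-431 cells (Homo sapiens) for cytotoxicity, read by MTT assay, with a stated time of 72 h, tested at 1 uM; a lower number here means less inhibition of growth, a higher number more inhibition of growth at the concentration tested.
Compound 2, `Cc1cccc(/C(N)=N/NC(=S)N2CCOCC2)n1`, gives 47.2% in this assay.
Compound 3, `N/C(=N\NC(=S)N1CCSCC1)c1ccc(F)cn1`, gives 48.7% in this assay.

The three measured compounds share a thiocarbonyl carbon carrying a saturated six-membered ring, and they differ in that ring or in the aromatic core. Compound 2 differs from compound 1 by morpholin-4-yl in place of thiomorpholin-4-yl on a thiocarbonyl carbon. The change gives a number 4.4 percentage points higher from compound 1 to compound 2 (within the scatter), so compound 1 and compound 2 cannot be told apart by this readout. Compound 3 carries a different core; the difference between the two cores is not broken down here. Its value sits near those of compound 1 and compound 2, and all three numbers lie within the usual scatter of one another.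

Compound 4, `N/C(=N\NC(=S)N1CCOCC1)c1ccc(F)cn1`, has not yet been measured in this assay. It differs from compound 3 by morpholin-4-yl in place of thiomorpholin-4-yl on a thiocarbonyl carbon, the same change that turns compound 1 into compound 2, made at the same place. Among the compounds with values here, the expectation rests on the one measured step of this kind, a number 4.4 percentage points higher from compound 1 to compound 2 (within the scatter), which was small. The step expected here is a number 3.3 percentage points higher from compound 3 to compound 4 (within the scatter), and it is estimated to stay within the scatter. Compound 4 is therefore expected to give about 52%, with a likely range from 40% to 64%.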

Compound 4, percent growth inhibition at one concentration: 31.8%
For compound 4 the middle estimate is 20.2 percentage points above the measured one; measured number outside the range, below it.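

Putting morpholin-4-yl in place of thiomorpholin-4-yl on a thiocarbonyl carbon gives, in this assay, a number 16.9 percentage points lower from compound 3 to compound 4 (beyond the scatter). A step measured on one core therefore did not predict the step on the other core in this small set, and the swap cannot be treated as having one fixed size across the series: the same change on two cores in this assay, a number 4.4 percentage points higher (within the scatter) from compound 1 to compound 2 and a number 16.9 percentage points lower (beyond the scatter) from compound 3 to compound 4, 21.3 percentage points apart, beyond the scatter of two such steps. Within the data shown here, this shows that the result of the swap depended on the core in these two pairs, but it does not show which feature of the core matters, why the two steps differ, or whether the same contrast would appear on any further core, since only two pairs are available for comparison.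

The compounds shown leave open how the same thiocarbonyl position would respond to other saturated rings, such as piperidin-1-yl, which has a plain carbon where these rings hold sulfur or oxygen, or piperazin-1-yl, which has a second nitrogen there. They also leave open whether a core carrying a chlorine atom in place of the fluorine would follow the step seen on one core, the step seen on the other, or neither.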